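A few compounds are considered here, and "the series" means these few. Any claim that something is new, unique, unknown or untested is made for them only; others in the source may bear on it.

Measured so far in this study:
compound 1, `Cc1nc(-c2ccc(F)cc2)ccc1C(=O)Nc1ccc2c(C)n[nH]c2c1`, gives 6.9
compound 2, `Cc1cc(-c2ccccc2)ncc1C(=O)Nc1ccc2cccnc2c1`, gives 6.7
compound 3, `Cc1nc(-c2ccccc2)ccc1C(=O)Nc1ccc2cccnc2c1`, gives 9

All three numbers come from an in vitro functional assay on 1321-N1 cells for antagonist activity at transient receptor potential cation channel subfamily V member 1 (Homo sapiens), read by FLIPR and calcium flux; a lower number here means a less potent compound, a higher number a more potent compound, by a factor of ten per unit of this negative logarithm. Compound 1 stands second highest of the three: its nearest neighbour is compound 2, whose number lies a little lower but within the scatter, while compound 3 lies far higher, beyond the scatter. Compound 4, `Cc1nc(-c2ccc(F)cc2)ccc1C(=O)Nc1ccc2cn[nH]c2c1`, has not been measured. It differs from compound 1 in one place: hydrogen in place of methyl on an aromatic carbon. Going by the values given here, no measured pair differs in a single place, so nothing here shows what the loss of a methyl does in this assay. The step of a number 0.20 log units lower from compound 1 to compound 4 (within the scatter) is expected to be small, within the scatter, in no firm direction. Compound 4 is therefore estimated at 6.7, within a range from 6 to 7.4.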

Compound 4, negative logarithm of the antagonist equilibrium constant: 7.5
The estimate for compound 4 lay 0.80 log units below the measured number; measured number above the stated range.
By their numbers in this assay, from the lowest: compounds 2 and 1 (each within the scatter of the next); then compound 4; then compound 3.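

Going by these compounds alone, the pair gives the first single-place comparison in the study. In this assay, hydrogen in place of methyl on this aromatic carbon of the five-membered ring gives a number 0.60 log units higher from compound 1 to compound 4 (beyond the scatter) and shows that the methyl is not required for activity in this series, at least on the core of compound 1. No measurement shown bears on the cause of this step. On these data alone, whether an ethyl group, a chlorine atom or an amine at this carbon would go with a higher or lower number remains open. As far as these compounds go, it also remains open whether the same change would give a similar step on the core of compound 3.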